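A few compounds are considered here, and "the series" means these few. Any claim that something is new, unique, unknown or untested is made for them only; others in the source may bear on it.

In a functional assay on PC-12 cells (Rattus norvegicus) for cytotoxicity, read by MTT assay, with a stated time of 24 h (a lower number here means that less compound is needed, a higher number that more compound is needed for the effect), compound 1 (`COc1ccc(N2CCN(CC#CCOC(=O)c3sc4ncnc(N5CCCCC5)c4c3C)CC2)cc1`) gives 35.3 ug/mL and compound 2 (`COc1cccc(N2CCN(CC#CCOC(=O)c3sc4ncnc(N5CCCCC5)c4c3C)CC2)c1`) gives 40.4 ug/mL. Compound 3 (`Cc1c(C(=O)OCC#CCN2CCN(c3cc(C4CC4)ccc3C#N)CC2)sc2ncnc(N3CCCCC3)c12`) gives 16.2 ug/mL, the lowest of the three numbers. Compound 4 (`Cc1c(C(=O)OCC#CCN2CCN(c3ccc(Br)cc3C#N)CC2)sc2ncnc(N3CCCCC3)c12`) is still unmeasured. It carries 4-bromo-2-cyanophenyl in place of 2-cyano-5-cyclopropylphenyl on an amine nitrogen in a ring. The closest evidence comes from changing the group at this same place. That gave a 2.2-fold lower number from compound 1 to compound 3 (0.34 log units; beyond the scatter) and a 2.5-fold lower number from compound 2 to compound 3 (0.40 log units; beyond the scatter), both modest, while the methoxy swap gave a 1.1-fold higher number from compound 1 to compound 2 (0.06 log units; within the scatter). Among the measured compounds shown here, no measured step swaps cyclopropyl for bromo alone, so in this assay no step beyond the scatter is expected. The expected change is a 1.2-fold higher number from compound 3 to compound 4 (0.09 log units; within the scatter). For compound 4 the estimate is 20 ug/mL, with an expected range of 10 ug/mL to 40 ug/mL.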

Compound 4, half-maximal effective concentration: 40.9 ug/mL
Compound 4: middle estimate off by 2.0-fold (0.31 log units), on the low side; measured number outside the range, above it.
By their numbers in this assay, from the lowest: compound 3; then compounds 1, 2 and 4 (each within the scatter of the next).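

Two groups that both carry a nitrile do not behave alike at this position: this assay shows a 2.5-fold higher number from compound 3 to compound 4 (0.40 log units; beyond the scatter) when 4-bromo-2-cyanophenyl replaces 2-cyano-5-cyclopropylphenyl. The nitrile alone therefore does not go with the low number of compound 3, and the methoxyphenyl compounds stand level with compound 4, with a 1.0-fold higher number from compound 2 to compound 4 (0.01 log units; within the scatter) and a 1.2-fold higher number from compound 1 to compound 4 (0.06 log units; within the scatter) in this assay. No measurement available here explains the difference.

Bromine and cyclopropyl also sit at different places on the phenyl ring, so which of these changes matters stays open. A 2-cyanophenyl group with no further substituent, or one carrying an amine, could help to separate them.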